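Bromo in Place of Ethyl: Where Compound 4 Should Land

The source may hold more compounds than are shown below. What is called first, only, known or untested is meant among the compounds shown, and "the series" means these compounds.

Compound 1, `Cc1ccc(C)c(-n2nncc2CN2C(=O)C3(C(C#N)=C(N)Oc4c3c3nc5ccccc5nc3c3ccccc43)c3ccccc32)c1`: in a functional assay on HCT-116 cells (Homo sapiens) for antiproliferative activity, read by MTT assay, with a stated time of 48 h (a lower number here means a stronger inhibitor, a higher number a weaker inhibitor), compound 1 gives > 50000 nM, a limit of the assay rather than a number.
Compound 2, `Cc1ccc(Cl)cc1-n1nncc1CN1C(=O)C2(C(C#N)=C(N)Oc3c2c2nc4ccccc4nc2c2ccccc32)c2ccccc21`: in this assay compound 2 gives > 50000 nM, again a limit.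
Compound 3, `CCc1ccccc1-n1nncc1CN1C(=O)C2(C(C#N)=C(N)Oc3c(N)cc4nc5ccccc5nc4c32)c2ccccc21`: in this assay compound 3 gives 10300 nM.

Compound 3 is therefore the only one of the three with a measured number; the two others sit at the limit of > 50000 nM in this assay, at which 2 of the 3 values shown sit. Compound 4, `N#CC1=C(N)Oc2c(N)cc3nc4ccccc4nc3c2C12C(=O)N(Cc1cnnn1-c1ccccc1Br)c1ccccc12`, differs from compound 3 in one place: bromo in place of ethyl on an aromatic carbon. Going by the values given here, no measured step matches this change. Among the compounds with values here, the only step available, a step that the two limits leave unreadable from compound 1 to compound 2, runs between two limits and its size cannot be read, so it gives no guidance. With nothing pointing to a shift in either direction, the expected step is a 1.0-fold lower number from compound 3 to compound 4 (0.01 log units; within the scatter), within the usual scatter. Compound 4 is thus estimated at 10000 nM, with a range from 3000 nM to 40000 nM.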

Compound 4, half-maximal inhibitory concentration: 12400 nM
Compound 4: the middle estimate sits 1.2-fold (0.09 log units) below what was measured; low and high end bracket the measured number.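

In this assay, bromo in place of ethyl on this six-membered aromatic ring gives a 1.2-fold higher number from compound 3 to compound 4 (0.08 log units; within the scatter). At this place, ortho to a large group, the 2-ethylphenyl and 2-bromophenyl compounds therefore cannot be told apart. This is the only readable step so far, as the earlier one cannot be read: the limit of > 50000 nM in this assay, at which 2 of the 4 values shown sit.

Going by these compounds, whether an amine, a carboxylic acid or a longer chain at this place would move the number stays open. So does whether this swap would read the same on the core of compound 1.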